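Moving the Substituent on the Silicon-Bound Phenyl Ring

The compounds below may be only part of what the source reports. "The series", "measured", "known", "first", "only" and "open" are said of these compounds alone.

Compound 1 `CCN(C/C=C/C#CC(C)(C)C)Cc1cccc(OC[Si](C)(C)c2ccc(F)cc2)c1` gives 60 nM in a functional assay on liver (Sus scrofa) for inhibition of squalene monooxygenase (Homo sapiens), using microsomes; a lower number here means a stronger inhibitor, a higher number a weaker inhibitor.
Compound 2 `CCN(C/C=C/C#CC(C)(C)C)Cc1cccc(OC[Si](C)(C)c2ccc(C)cc2)c1` gives 120 nM in this assay.
Compound 3 `CCN(C/C=C/C#CC(C)(C)C)Cc1cccc(OC[Si](C)(C)c2ccccc2C)c1` gives 30 nM in this assay.

Of the three measured compounds, compound 3 has the lowest number; its gap to compound 1 is within the scatter, and only its gap to compound 2 is beyond it. Compound 4 `CCN(C/C=C/C#CC(C)(C)C)Cc1cccc(OC[Si](C)(C)c2ccc(O)cc2)c1` has not yet been measured. It differs from compound 3 in one place: 4-hydroxyphenyl in place of 2-methylphenyl on a silicon. Among the measured compounds shown here, two measured steps bear on this change, since both end at the 2-methylphenyl ring of compound 3 and start from a ring carrying its substituent in the 4-position: a 2.0-fold lower number from compound 1 to compound 3 (0.30 log units; within the scatter) and a 4.0-fold lower number from compound 2 to compound 3 (0.60 log units; beyond the scatter). Going the other way, from 2-methylphenyl to a 4-substituted ring, would therefore be expected to raise the number somewhat. For the measured compounds named here, no measured compound carries a hydroxyl group, so that part of the change is not covered by any step. On this basis compound 4 is expected to give 90 nM in this assay, with a range from 30 nM to 300 nM, which means an expected step of a 3.0-fold higher number from compound 3 to compound 4 (0.48 log units; beyond the scatter).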

Compound 4, half-maximal inhibitory concentration: 8000 nM
Compound 4: middle estimate off by 89-fold (1.95 log units), on the low side; the measured number lies above the stated range.
By their numbers in this assay, from the lowest: compounds 3, 1 and 2 (each within the scatter of the next, the first and the last beyond it); then compound 4.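

Hydroxy behaves very differently from the earlier ring substituents in this assay: in place of methyl it gives a 67-fold higher number from compound 2 to compound 4 (1.82 log units; beyond the scatter), and in place of fluoro it gives a 130-fold higher number from compound 1 to compound 4 (2.12 log units; beyond the scatter). Replacing the 2-methylphenyl on the silicon with 4-hydroxyphenyl gives a 270-fold higher number from compound 3 to compound 4 (2.43 log units; beyond the scatter), whereas the largest step among the earlier rings was a 4.0-fold lower number from compound 2 to compound 3 (0.60 log units; beyond the scatter), so the choice of group at this place can matter far more than those compounds showed. No measurement shown here explains this loss.

Going by these compounds, whether a methoxy or an amino group on the same ring would give a number like that of compound 4, or one like those of compound 1 and compound 2, stays open. So does the effect of 2-hydroxyphenyl on the silicon.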